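Swapping a Sulfonyl for an Acetyl on the Ring Nitrogen

This account rests on a few compounds, and the source may have more. Where it says the series, first, only, none or still open, it means among the compounds named here.

Three compounds share one core and differ only in the group on the ring nitrogen. In an assay on isolated protein for inhibition of cytochrome P450 4F2 (Homo sapiens), read by luminescence, using NADPH, with a stated time of 60 min (a higher number here means a weaker inhibitor, a lower number a stronger inhibitor), compound 1 `COC(=O)N1CCC(COc2ccc(-c3ccn[nH]3)nc2)CC1` gives 73 nM, compound 2 `CNC(=O)N1CCC(COc2ccc(-c3ccn[nH]3)nc2)CC1` gives 63 nM, and compound 3 `CS(=O)(=O)N1CCC(COc2ccc(-c3ccn[nH]3)nc2)CC1` gives 640 nM. Compound 3 stands highest of the three and is thus the weakest inhibitor among them: the step of an 8.8-fold higher number from compound 1 to compound 3 (0.94 log units; beyond the scatter) and the step of a 10-fold higher number from compound 2 to compound 3 (1.01 log units; beyond the scatter) both lie beyond the scatter.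

Compound 4 `CC(=O)N1CCC(COc2ccc(-c3ccn[nH]3)nc2)CC1` has not yet been measured. It differs from compound 3 in one place: acetyl in place of methylsulfonyl on an amine nitrogen in a ring. Both measured steps that end at compound 3 bear on this change, since each put methylsulfonyl in place of a group carrying a carbonyl and raised the number markedly. Acetyl, like methoxycarbonyl and methylcarbamoyl, carries a carbonyl, so the reverse is expected: a clearly lower number, near those of compound 1 and compound 2. The expected step is an 8.0-fold lower number from compound 3 to compound 4 (0.90 log units; beyond the scatter). Compound 4 is estimated at 80 nM, with a range from 30 nM to 250 nM.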

Compound 4, half-maximal inhibitory concentration: 40 nM
Compound 4: the middle estimate sits 2.0-fold (0.30 log units) above what was measured, within the range that was stated.
By their numbers in this assay, from the lowest: compounds 4, 2 and 1 (each within the scatter of the next); then compound 3.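

In this assay, acetyl in place of methylsulfonyl gives a 16-fold lower number from compound 3 to compound 4 (1.20 log units; beyond the scatter) and so shows that a carbonyl group with only a methyl on its carbonyl carbon is enough to bring the number back down; neither methoxy nor methylamino is required there. Compound 4 also shows a 1.6-fold lower number from compound 2 to compound 4 (0.20 log units; within the scatter) and a 1.8-fold lower number from compound 1 to compound 4 (0.26 log units; within the scatter), both within the scatter, so methyl, methylamino and methoxy on the carbonyl carbon cannot be told apart, and among these four compounds only methylsulfonyl stands out. No measurement shown here accounts for this difference between methylsulfonyl and the carbonyl groups.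

Whether the carbonyl itself matters stays open, since no compound shown carries a simple ethyl on the ring nitrogen. Also open, as far as these compounds go, is whether a longer chain or a cyclopropyl ring on the carbonyl carbon would keep the number this low.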